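The source may hold more compounds than are shown below. What is called first, only, known or untested is meant among the compounds shown, and "the series" means these compounds.

Working notes on the series, read in an in vitro ADME assay on microsomes from liver (Rattus norvegicus) for metabolic stability; a lower number here means that the compound disappears faster, a higher number that the compound lasts longer. Compound 1 (`Cc1nc2ccc(-c3ccccc3Cl)c(CN)c2n1C`) gives 0.117 h, compound 3 (`Cn1cnc2ccc(-c3ccccc3CO)c(CN)c21`) gives 0.65 h, and compound 2 (`CCn1cnc2ccc(-c3ccc(Cl)cc3Cl)c(CN)c21`) gives 0.7 h. Compound 2 therefore sits within the scatter of compound 3, and compound 1 lies lower than compound 2 by a margin beyond the scatter. The next compound to be read is compound 4 (`NCc1c(-c2ccc(Cl)cc2Cl)ccc2nc[nH]c12`), which differs from compound 2 in one place: hydrogen in place of ethyl on an aromatic nitrogen. In plain terms, this is hydrogen in place of ethyl on an aromatic nitrogen.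

Within the data shown here, no pair of measured compounds isolates a change at this nitrogen, so the series offers no direct guide to the step. Among the measured compounds shown here, the only anchor is compound 2 at 0.7 h, and a shift beyond the scatter is not expected in either direction. The expected step, a 1.1-fold higher number from compound 2 to compound 4 (0.06 log units; within the scatter), is small and slightly upward, within the scatter. Compound 4 is expected at 0.8 h, with an estimated range of 0.3 h to 2 h.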

Compound 4, half-life: 0.767 h
Estimate against measurement, compound 4: 1.0-fold (0.02 log units) above, within the range that was stated.
By their numbers in this assay, from the lowest: compound 1; then compounds 3, 2 and 4 (each within the scatter of the next).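

In this assay, among these compounds, the pair gives the first direct reading of a change on this aromatic nitrogen: a 1.1-fold higher number from compound 2 to compound 4 (0.04 log units; within the scatter) shows that hydrogen in place of ethyl leaves the half-life indistinguishable. Losing the ethyl, with its 2 heavy atoms, therefore produces no readable shift on the shared core of this pair. No measurement at hand accounts for this result.

Going by these compounds, only ethyl and hydrogen are compared on this nitrogen, so the reading for a longer chain, or for a chain carrying an amine or a carboxylic acid, remains open. Also open, on these data alone, is whether the same change would read alike on the cores of compound 1 and compound 3, which differ from this pair in more than one place.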